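Third fluorine on the phenoxy ring of the series

The source may hold more compounds than are shown below. What is called first, only, known or untested is meant among the compounds shown, and "the series" means these compounds.

Within the data shown here, compound 2 `CC(C)[C@H](NC(=O)COc1cccc2ccccc12)C(=O)N[C@@H](CC(=O)O)C(=O)COc1ccc(F)cc1F` gives the highest of the two numbers so far: in a functional assay on Jurkat cells (Homo sapiens) (on this read-out higher numbers stand for weaker inhibition and lower numbers for stronger inhibition), compound 2 gives 33200 nM, while compound 1 `CC(C)[C@H](NC(=O)COc1cccc2ccccc12)C(=O)N[C@@H](CC(=O)O)C(=O)COc1ccccc1` gives 14000 nM. Among the measured compounds shown here, the one step on record, a 2.4-fold higher number from compound 1 to compound 2 (0.38 log units; beyond the scatter), shows that adding fluoro to this ring raised the number modestly. Compound 3 `CC(C)[C@H](NC(=O)COc1cccc2ccccc12)C(=O)N[C@@H](CC(=O)O)C(=O)COc1cc(F)c(F)cc1F` carries the change (fluoro in place of hydrogen on an aromatic carbon). For the measured compounds named here, that same step is the only guide here, so a further modest rise, or a step within the scatter, is expected for compound 3, namely a 1.4-fold higher number from compound 2 to compound 3 (0.13 log units; within the scatter). Compound 3 is therefore estimated at 45000 nM, with a range from 18000 nM to 110000 nM.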

Compound 3, half-maximal inhibitory concentration: 39300 nM
Compound 3: middle estimate off by 1.1-fold (0.06 log units), on the high side, within the range that was stated.
By their numbers in this assay, from the lowest: compound 1; then compounds 2 and 3 (each within the scatter of the next).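

Going from 2,4-difluorophenoxy to 2,4,5-trifluorophenoxy gives a 1.2-fold higher number from compound 2 to compound 3 (0.07 log units; within the scatter) in this assay, so this third fluoro cannot be told apart from the difluoro compound on this read-out. The gap to the unsubstituted phenyl remains, with a 2.8-fold higher number from compound 1 to compound 3 (0.45 log units; beyond the scatter) for the 2,4,5-trifluorophenyl group. No measurement in hand explains these numbers. As far as these compounds go, it remains open whether a single fluoro on this ring already accounts for the rise, and whether a methoxy group or an amine on the ring would bring the number back toward that of compound 1.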